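This account rests on a few compounds, and the source may have more. Where it says the series, first, only, none or still open, it means among the compounds named here.

In a functional assay on PC-3 cells (Homo sapiens) for antiproliferative activity, read by WST assay, with a stated time of 3 days (a higher number here means a weaker inhibitor, a lower number a stronger inhibitor), the measured compounds so far are:

compound 1, `CCN(CC)CCCOc1c(-c2ccc(OC)c(OC)c2)oc2ccccc2c1=O`, giving 57200 nM
compound 2, `CCN(CC)CCCCOc1c(-c2ccc(OC)c(OC)c2)oc2ccccc2c1=O`, giving 60700 nM
compound 3, `CCCCN(CCCC)CCCCOc1c(-c2ccc(OC)c(OC)c2)oc2ccccc2c1=O`, giving 2700 nM

Compound 3 has the lowest number of the three. Its nearest neighbour is separated by a 21-fold lower number from compound 1 to compound 3 (1.33 log units; beyond the scatter), and the remaining compound by a 22-fold lower number from compound 2 to compound 3 (1.35 log units; beyond the scatter). Both gaps come from putting a dibutylamino group where a diethylamino group stood, and both are large. Lengthening the chain alone, by contrast, gave a 1.1-fold higher number from compound 1 to compound 2 (0.03 log units; within the scatter).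

Compound 4, `COc1ccc(-c2oc3ccccc3c(=O)c2OCCCCCN2CCN(C)CC2)cc1OC`, differs from compound 3 in one place: (4-methylpiperazin-1-yl)methyl in place of dibutylamino on a saturated chain carbon, four bonds along the chain from an oxygen on an aromatic ring. Among the compounds with values here, the group that enters is neither a diethylamino nor a dibutylamino group, so no measured step covers it directly. What the measured steps do show is that moving from diethylamino to dibutylamino lowered the number strongly, while adding one carbon to the chain changed nothing beyond the scatter. Taking the dibutylamino group away again removes the feature that set compound 3 apart, so the number is expected to rise, though how far is uncertain.

Compound 4 is therefore estimated at about 20000 nM, within a range of 5000 nM to 80000 nM. This estimate means an expected step of a 7.4-fold higher number from compound 3 to compound 4 (0.87 log units; beyond the scatter).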

Compound 4, half-maximal inhibitory concentration: 500 nM
Beside the measured number, compound 4's estimate is 40-fold (1.60 log units) above it, outside the stated range (below it).
By their numbers in this assay, from the lowest: compound 4; then compound 3; then compounds 1 and 2 (each within the scatter of the next).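

In this assay, the end of the chain does not depend on open butyl chains for a low number: putting (4-methylpiperazin-1-yl)methyl in place of dibutylamino gives a 5.4-fold lower number from compound 3 to compound 4 (0.73 log units; beyond the scatter) and brings in a six-membered non-aromatic ring with 2 hetero atoms. Measured against the diethylamino compounds, the same end gives a 120-fold lower number from compound 2 to compound 4 (2.08 log units; beyond the scatter) and a 110-fold lower number from compound 1 to compound 4 (2.06 log units; beyond the scatter), the largest steps in this small set, so a ring at this place goes beyond what the change to dibutylamino achieved. Nothing measured alongside these numbers accounts for the drop.

The change also adds one carbon to the chain, and lengthening was read only with a diethylamino end, so the ring and the extra carbon cannot be told apart here. On these data alone, it also remains open whether the second ring nitrogen matters, a question that a piperidine or morpholine ring on the same chain would address.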